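Toxicity Check on a Methylated Triazole Sulfonamide

A few compounds are considered here, and "the series" means these few. Any claim that something is new, unique, unknown or untested is made for them only; others in the source may bear on it.

Compound 1 `O=c1[nH]cc(S(=O)(=O)Nc2ccccc2-c2cn(-c3cccc(Cl)c3)nn2)c(=O)[nH]1`: > 100000 nM
Compound 2 `Cc1ccccc1-n1cc(-c2cccc(NS(=O)(=O)c3c[nH]c(=O)[nH]c3=O)c2)nn1`: 21500 nM
Compound 3 `O=c1[nH]cc(S(=O)(=O)Nc2ccc(-c3cn(-c4ccccc4)nn3)cc2)c(=O)[nH]1`: "not toxic" (no number reported)

All three measurements come from an ADME assay on GES1 cells (Homo sapiens) for cytotoxicity, read by MTT assay, with a stated time of 24 h; on this read-out lower numbers stand for higher toxicity in this test and higher numbers for lower toxicity in this test. Compound 1 reaches only a limit in this assay, (the limit of > 100000 nM in this assay, at which 1 of the 3 values shown sits), so no number stands behind it. Compound 2 gives a proper value, 21500 nM. Going by the values given here, compound 3 is reported as "not toxic" (no number reported), with no number at all, so it cannot be placed above or below compound 2 on this scale; all that can be said is that it joins compound 1 among the compounds without a measured value, while compound 2 is the only one with a number.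

Compound 4 `Cc1ccccc1-n1cc(-c2ccc(NS(=O)(=O)c3c[nH]c(=O)[nH]c3=O)cc2)nn1` differs from compound 3 by methyl in place of hydrogen on an aromatic carbon. No measured step in this assay covers this change, so its size has to be guessed from what is shown. Compound 2 carries the same methyl group on the same kind of ring and gives 21500 nM, which suggests that a number, rather than a limit, could appear, and that any shift from compound 3 would be toward a lower value; whether that shift would exceed the scatter cannot be judged from these data. For compound 4 a half-maximal cytotoxic concentration of 60000 nM is expected, with a range from 15000 nM to 200000 nM.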

Compound 4, half-maximal cytotoxic concentration: "not toxic" (no number reported)
For compound 4 the study gives words and no number; the estimate stays without a comparison.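

In this assay, going by these compounds alone, compound 3 and compound 4 are both reported only as "not toxic", without a number, and no step between them can be read. The compounds shown leave open how far the change from phenyl to 2-methylphenyl moves the half-maximal cytotoxic concentration. Nothing shown bears on this result.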